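The compounds below may be only part of what the source reports. "The series", "measured", "known", "first", "only" and "open" are said of these compounds alone.

Measured compounds in hand:
- compound 1 `CCn1cc(-c2nc3ccc([N+](=O)[O-])cc3[nH]2)c(=O)c2cc(F)c(N3CCNCC3)nc21`: 12400 nM
- compound 2 `CCn1cc(-c2nc3ccc([N+](=O)[O-])cc3[nH]2)c(=O)c2cc(F)c(N3CCN(C)CC3)cc21`: 4700 nM
- compound 3 `CCn1cc(-c2nc3ccc(N)cc3[nH]2)c(=O)c2cc(F)c(N3CCN(C)CC3)cc21`: > 50000 nM

In a functional assay on A2780 cells (Homo sapiens) for cytotoxicity, read by MTT assay, with a stated time of 48 h (on this read-out higher numbers stand for weaker inhibition and lower numbers for stronger inhibition), compound 1 gives 12400 nM, while compound 2 gives 4700 nM, so compound 1 holds the higher of the two numbers, the gap to compound 2 lying beyond the scatter. The difference between the two cores is not broken down here. For compound 3 the value in this assay is a limit of the assay and not a number: > 50000 nM. The change from compound 2 to compound 3 is amino in place of nitro on an aromatic carbon; it produced an at least 10-fold higher number from compound 2 to compound 3 (1.02 log units; beyond the scatter), and compound 3 sits at the limit of > 50000 nM in this assay, at which 1 of the 3 values shown sits.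

The unmeasured compound 4 `CCn1cc(-c2nc3ccc(N)cc3[nH]2)c(=O)c2cc(F)c(N3CCNCC3)nc21` is reached from compound 1 by the same change, (amino in place of nitro on an aromatic carbon). Because compound 1 already starts from the higher number 12400 nM, a step of similar size is expected to carry compound 4 to a still higher number. The expected step is a 9.7-fold higher number from compound 1 to compound 4 (0.99 log units; beyond the scatter), resting on an at least 10-fold higher number from compound 2 to compound 3 (1.02 log units; beyond the scatter). For compound 4 the estimate in this assay is 120000 nM, with an expected range from 35000 nM to 400000 nM, most likely reported only as a limit.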

Compound 4, half-maximal inhibitory concentration: 42300 nM
Estimate against measurement, compound 4: 2.8-fold (0.45 log units) above; low and high end bracket the measured number.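

In this assay, amino in place of nitro on an aromatic carbon gives a 3.4-fold higher number from compound 1 to compound 4 (0.53 log units; beyond the scatter) in the same direction as on the other core, but the size of the step does not carry over: the same change on two cores in this assay, an at least 10-fold higher number (1.02 log units; beyond the scatter) from compound 2 to compound 3 and a 3.4-fold higher number (0.53 log units; beyond the scatter) from compound 1 to compound 4, at least 3.1-fold (0.49 log units) apart, beyond the scatter of two such steps.
The value of compound 3 is a limit of the assay and not a number: > 50000 nM.
The direction of the change thus holds on both cores, while the step on the core of compound 2 has only a lower bound, and two pairs neither give a rule for the size on a further core nor show which difference between the cores goes with the gap.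

The compounds shown leave open how other groups on that aromatic carbon, such as a nitrile or a carboxylic acid, would stand against nitro and amino. They also leave open how the step would run on a core carrying only one of the differences between the two cores.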